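A few compounds are considered here, and "the series" means these few. Any claim that something is new, unique, unknown or untested is made for them only; others in the source may bear on it.

Measured so far:
compound 1, `COc1ccccc1C1C(C#N)=C(N)N(c2ccc(S(N)(=O)=O)cc2)C2=C1CCCC2`: 40% in a functional assay on Ehrlich cells (Mus musculus) for cytotoxicity, read by trypan blue exclusion, with a stated time of 2 h, tested at 25 ug/mL; a lower number here means a weaker effect, a higher number a stronger effect of the compound at the concentration tested
compound 2, `N#CC1=C(N)N(c2ccc(S(N)(=O)=O)cc2)C2=C(CCCC2)C1c1cccc([N+](=O)[O-])c1`: 1%
compound 3, `N#CC1=C(N)N(c2ccc(S(N)(=O)=O)cc2)C2=C(CCCC2)C1c1ccc([N+](=O)[O-])cc1`: 5%

Compound 3 stands second highest of the three numbers in this assay. Its nearest neighbour is compound 2, and the step of a number 4 percentage points higher from compound 2 to compound 3 (within the scatter) lies within the scatter, so the two cannot be ordered. Its furthest neighbour is compound 1, which stands beyond the scatter above it, as the step of a number 35 percentage points lower from compound 1 to compound 3 (beyond the scatter) shows.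

Compound 4, `Cc1ccc(C2C(C#N)=C(N)N(c3ccc(S(N)(=O)=O)cc3)C3=C2CCCC3)o1`, differs from compound 3 in one place: 5-methylfuran-2-yl in place of 4-nitrophenyl on a saturated ring carbon. Within the data shown here, two measured steps bear on this, both exchanges of the group on that saturated ring carbon: a number 39 percentage points lower from compound 1 to compound 2 (beyond the scatter) and a number 35 percentage points lower from compound 1 to compound 3 (beyond the scatter), each large. The third, a number 4 percentage points higher from compound 2 to compound 3 (within the scatter), is within the scatter. So the group on that carbon can move the read-out a great deal, but no measured compound carries a 5-methylfuran-2-yl, and no measured step leads upward from a nitrophenyl compound. Compound 4 is therefore expected to move in this assay by a number 15 percentage points higher from compound 3 to compound 4 (beyond the scatter), a rise whose size is uncertain. The estimate for compound 4 is 20%, with a range from 3% to 45%.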

Compound 4, a percentage reported as activity, at one concentration (the size of the read-out at that concentration, not a potency): 10%
For compound 4 the middle estimate is 10 percentage points above the measured one, within the range that was stated.
By their numbers in this assay, from the lowest: compounds 2, 3 and 4 (each within the scatter of the next); then compound 1.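

In this assay the exchange of 4-nitrophenyl for 5-methylfuran-2-yl gives a number 5 percentage points higher from compound 3 to compound 4 (within the scatter) and the exchange of 3-nitrophenyl for the same group gives a number 9 percentage points higher from compound 2 to compound 4 (within the scatter), so compound 4 cannot be told apart from either nitrophenyl compound. The low read-out on this saturated ring carbon is thus not confined to nitrophenyl groups: a group with a five-membered aromatic ring and no nitrogen gives the same picture, while the step to the 2-methoxyphenyl compound, a number 30 percentage points lower from compound 1 to compound 4 (beyond the scatter), leaves compound 1 as the only one of the four that stands clear of the others. Nothing available explains why the 2-methoxyphenyl group stands apart from the other three groups.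

The compounds shown leave open whether the higher read-out of compound 1 depends on the methoxy group itself or on where it sits, which a 4-methoxyphenyl or an unsubstituted phenyl group on the same carbon would help to settle. They also leave open whether a 2-hydroxyphenyl or a 2-aminophenyl group would keep that read-out, and whether the methyl group of the 5-methylfuran-2-yl group matters at all, as a plain furan-2-yl group could show.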